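Shifting the pyrazole attachment in an antiproliferative pair

The compounds below may be only part of what the source reports. "The series", "measured", "known", "first", "only" and "open" are said of these compounds alone.

In a functional assay on MCF7 cells (Homo sapiens) for antiproliferative activity, read by CellTiter-Glo, with a stated time of 5 days (on this read-out higher numbers stand for weaker inhibition and lower numbers for stronger inhibition), compound 1 (`CC/C(=C(/c1ccc(/C=C/C(=O)O)cc1)c1ccc(-c2cscn2)cc1)c1ccccc1`) gives 120 nM and compound 2 (`CC/C(=C(/c1ccc(/C=C/C(=O)O)cc1)c1ccc(-c2cc[nH]n2)cc1)c1ccccc1`) gives 440 nM. Compound 2 therefore holds the higher of the two numbers and is the weaker inhibitor of the pair. Compound 3 (`CC/C(=C(/c1ccc(/C=C/C(=O)O)cc1)c1ccc(-c2cn[nH]c2)cc1)c1ccccc1`) has the same atoms as compound 2, joined differently: 1H-pyrazol-4-yl in place of 1H-pyrazol-3-yl on an aromatic carbon. Here 1H-pyrazol-4-yl stands in place of 1H-pyrazol-3-yl on an aromatic carbon, para to a large group. Among the measured compounds shown here, only one measured step bears on this change: a 3.7-fold higher number from compound 1 to compound 2 (0.56 log units; beyond the scatter), a modest step beyond the scatter that came from replacing 1,3-thiazol-4-yl with 1H-pyrazol-3-yl. For the measured compounds named here, it shows that the number in this assay can respond to a change of ring at this place, but no measured pair isolates a shift between pyrazole isomers. A step smaller than that one is expected, with only a slight lean towards a lower number, resting on compound 1 at 120 nM. The expected result is a 1.5-fold lower number from compound 2 to compound 3 (0.17 log units; within the scatter). For compound 3 the estimated value is 300 nM, with an expected range of 100 nM to 900 nM.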

Compound 3, half-maximal inhibitory concentration: 40 nM
Compound 3: the middle estimate sits 7.5-fold (0.88 log units) above what was measured; measured number below the stated range.
By their numbers in this assay, from the lowest: compound 3; then compound 1; then compound 2.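

At this place, on an aromatic carbon para to a large group, the point at which the pyrazole is joined matters as well as the choice of ring: in this assay there is an 11-fold lower number from compound 2 to compound 3 (1.04 log units; beyond the scatter) even though the atoms are the same and the counts of hydrogen-bond donors and acceptors do not differ. The earlier pair had shown only that exchanging one ring for another could move the number, whereas there is now also a 3.0-fold lower number from compound 1 to compound 3 (0.48 log units; beyond the scatter) and the two pyrazole isomers fall on opposite sides of compound 1, each beyond the scatter, so 1H-pyrazol-3-yl does not speak for pyrazoles as a class in this series. Among the compounds shown here, nothing available explains why the joining of the ring moves the number so far.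

The compounds shown leave open whether a methyl group on the 1H-pyrazol-4-yl ring, or an imidazole ring or a 1,2,3-triazole ring at the same place, would keep the number of compound 3. They also leave open whether this ordering of rings would hold if the carboxylic acid of the shared core gave way to a primary amide.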